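The compounds below may be only part of what the source reports. "The series", "measured", "known", "first", "only" and "open" are said of these compounds alone.

Measured compounds in a functional assay on KB cells (Homo sapiens) for antiproliferative activity, read by MTT assay, with a stated time of 72 h; a higher number here means a weaker inhibitor, a lower number a stronger inhibitor:
- compound 1, `O=C(Nc1cccc(F)c1)C(Cl)Cl` — "not determined" (no result reported)
- compound 2, `N#Cc1cccc(NC(=O)C(Cl)Cl)c1` — 60900 nM
- compound 3, `O=C(Nc1cccc([N+](=O)[O-])c1)C(Cl)Cl` — 44700 nM

Compound 1 stands nowhere on these numbers: in this assay compound 1 has no single value, so its place relative to compound 2 and compound 3 is open. Going by the values given here, the only step between measured compounds is a 1.4-fold lower number from compound 2 to compound 3 (0.13 log units; within the scatter), a change at the same position of the shared core as the one now under study, but with different groups.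

Compound 4, `O=C(Nc1cccc(OC(F)(F)F)c1)C(Cl)Cl`, differs from compound 1 by trifluoromethoxy in place of fluoro on an aromatic carbon. Among the compounds with values here, no measured step bears directly on this exchange of fluoro for trifluoromethoxy; the one step available concerns nitro and cyano and shows a difference within the scatter. Within the data shown here, from that, no step of any particular size or direction can be expected in this assay from compound 1 to compound 4, and with compound 1 unmeasured there is no starting point from which a step could be read.

The estimate therefore rests on the two measured neighbours. Compound 4 is expected to give about 45000 nM in this assay, with a range from 12000 nM to 150000 nM.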

Compound 4, half-maximal inhibitory concentration: 7410 nM
Compound 4: middle estimate off by 6.1-fold (0.78 log units), on the high side; the measured number lies below the stated range.
By their numbers in this assay, from the lowest: compound 4; then compounds 3 and 2 (each within the scatter of the next).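

In this assay, the aromatic carbon that carries the varied group proved able to change the result: nitro and cyano had stayed within the scatter of each other, whereas trifluoromethoxy gives a 6.0-fold lower number from compound 3 to compound 4 (0.78 log units; beyond the scatter) and an 8.2-fold lower number from compound 2 to compound 4 (0.91 log units; beyond the scatter). The exchange of fluoro for trifluoromethoxy itself cannot be read, since compound 1 has only the entry "not determined" (no result reported) and offers no number from which to measure a step. Nothing available here accounts for the lower number of compound 4, so the difference stands as an observation without an explanation.

The compounds shown leave open whether this lower number belongs to trifluoromethoxy alone or would also appear with other groups on the same aromatic carbon, such as a methoxy group, an amine, a carboxylic acid or a longer alkyl chain. Going by these compounds alone, they also leave open how compound 1, with its single fluoro group, would compare with compound 4 in this assay, and therefore whether the larger group enters with any gain over the smaller one.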